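Chloro for Fluoro on the Urea Phenyl Ring

The source may report more compounds than this note shows. Statements on the series, on what has been measured and on what is new or still open speak of the compounds shown alone.

Measured so far:
compound 1, `CN(C)CCCNc1nc(-c2ccc(NC(=O)Nc3ccccc3F)cc2)nc2ccsc12`, giving 470 nM in a functional assay on HT-29 cells (Homo sapiens) for cytotoxicity, read by MTT assay, with a stated time of 72 h; on this read-out higher numbers stand for weaker inhibition and lower numbers for stronger inhibition;
compound 2, `CN(C)CCCNc1nc(-c2ccc(NC(=O)Nc3ccccc3Cl)cc2)nc2ccsc12`, giving 390 nM in this assay;
compound 3, `CN(C)CCNc1nc(-c2ccc(NC(=O)Nc3ccc(F)cc3)cc2)nc2c(Cl)c(Cl)sc12`, giving 890 nM in this assay.

Compound 4, `CN(C)CCNc1nc(-c2ccc(NC(=O)Nc3ccc(Cl)cc3)cc2)nc2c(Cl)c(Cl)sc12`, has not yet been measured in this assay. It is related to compound 3 by chloro in place of fluoro on an aromatic carbon. The pair compound 1 and compound 2 carries a change of the same kind, (chloro in place of fluoro on an aromatic carbon); in that pair the chloro sits ortho to a large group, whereas in compound 4 it sits para to a large group, so the two changes are alike in kind but not the same. Measured, the earlier step reads a 1.2-fold lower number from compound 1 to compound 2 (0.08 log units; within the scatter). The difference between the core of compound 1 and the core of compound 3 is not broken down here. Compound 3 and compound 2 differ by a gap beyond the scatter, while the gap between compound 3 and compound 1 lies within it.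

Because the earlier step of a 1.2-fold lower number from compound 1 to compound 2 (0.08 log units; within the scatter) lay within the scatter, a step of similar size is expected here, a 1.2-fold lower number from compound 3 to compound 4 (0.08 log units; within the scatter). Compound 4 is therefore expected to give about 740 nM in this assay. The estimate for compound 4 is expected to fall between 350 nM and 1600 nM.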

Compound 4, half-maximal inhibitory concentration: 460 nM
The estimate for compound 4 lay 1.6-fold (0.21 log units) above the measured number, within the range that was stated.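

In this assay, putting chloro in place of fluoro on the dichlorinated core gave a 1.9-fold lower number from compound 3 to compound 4 (0.29 log units; within the scatter), so this step, like the earlier one, does not stand clear of the usual scatter of repeated measurements. Set side by side, the two steps give no sign that the change behaves differently from one core to the other: the same change on two cores in this assay, a 1.2-fold lower number (0.08 log units; within the scatter) from compound 1 to compound 2 and a 1.9-fold lower number (0.29 log units; within the scatter) from compound 3 to compound 4, 1.6-fold (0.21 log units) apart, within the scatter of two such steps. This supports carrying the exchange between these two cores only as a change with no resolved effect; it does not show that chloro improves on fluoro, and it cannot separate the influence of the core from that of the chloro's place, since the chloro in compound 4 sits para to a large group while that in compound 2 does not, and two pairs say nothing about any further core.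

The compounds shown leave open how bromo, methyl or methoxy would read in the same place on the urea phenyl ring, and whether an unsubstituted phenyl would stand apart from the halogenated ones. They also leave open whether the exchange would read alike with a morpholine or a piperazine in place of the dimethylamino group at the end of the side chain.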